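This account rests on a few compounds, and the source may have more. Where it says the series, first, only, none or still open, it means among the compounds named here.

Among the measured compounds shown here, compound 2 `CC1CCN(C2CCN(S(=O)(=O)c3ccc(Cl)c(Cl)c3)CC2)CC1` gives 2.9 nM in a functional assay on DLD-1 cells (Homo sapiens) for antiproliferative activity, read by CellTiter-Glo, with a stated time of 72 h (on this read-out higher numbers stand for weaker inhibition and lower numbers for stronger inhibition), and holds the lowest number of the three measured members. Compound 1 `Cc1cccc(S(=O)(=O)N2CCC(N3CCC(C)CC3)CC2)c1` gives 25 nM and compound 3 `CC1CCN(C2CCN(S(=O)(=O)c3ccc(Cl)c(C(F)(F)F)c3)CC2)CC1` gives 17 nM; the steps of an 8.6-fold lower number from compound 1 to compound 2 (0.94 log units; beyond the scatter) and a 5.9-fold higher number from compound 2 to compound 3 (0.77 log units; beyond the scatter) show that each change of the aryl group on the sulfonyl sulfur has moved the read-out well beyond the scatter. Compound 4 `CC1CCN(C2CCN(S(=O)(=O)c3ccc(Cl)nc3)CC2)CC1` differs by 6-chloropyridin-3-yl in place of 3,4-dichlorophenyl on a sulfonyl sulfur, the sulfonyl sulfur keeping its sulfonamide nitrogen in a ring. Both known steps bear on this change, and both point toward higher numbers whenever the 3,4-dichlorophenyl group is altered, so a modest rise is expected: a 5.2-fold higher number from compound 2 to compound 4 (0.71 log units; beyond the scatter). Compound 4 is accordingly estimated at 15 nM, with a range from 4 nM to 60 nM.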

Compound 4, half-maximal inhibitory concentration: 3700 nM
Compound 4: the middle estimate sits 250-fold (2.39 log units) below what was measured; the whole stated range lies below it.
By their numbers in this assay, from the lowest: compound 2; then compounds 3 and 1 (each within the scatter of the next); then compound 4.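

In this assay 6-chloropyridin-3-yl on the sulfonyl sulfur brings a 1300-fold higher number from compound 2 to compound 4 (3.11 log units; beyond the scatter) against 3,4-dichlorophenyl and a 150-fold higher number from compound 1 to compound 4 (2.17 log units; beyond the scatter) against 3-methylphenyl, both large where the earlier aryl changes were modest. The three aromatic rings of carbon only, in compounds 1, 2 and 3, all give far lower numbers than the ring with a hetero atom in compound 4. Nothing measured here explains this loss.

Compound 4 swaps a ring carbon for nitrogen and drops a chlorine in one step, so the two changes remain inseparable. A phenyl ring with a single chlorine, or a pyridine ring with two chlorines, would separate them.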